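A fluorophenyl hydrazone weighed against its pyridyl counterpart

The source may hold more compounds than are shown below. What is called first, only, known or untested is meant among the compounds shown, and "the series" means these compounds.

Three hydrazones sharing one core have been measured in an ADME assay on THP-1 cells (Homo sapiens) for cytotoxicity; a higher number here means a weaker inhibitor, a lower number a stronger inhibitor. Compound 1 `COc1ccccc1-c1nnc(-c2ccc(C(=O)N/N=C/c3cccc(F)c3)cc2)o1` gives 353000 nM; compound 2 `COc1ccccc1-c1nnc(-c2ccc(C(=O)N/N=C/c3ccccc3[N+](=O)[O-])cc2)o1` gives 161000 nM; compound 3 `COc1ccccc1-c1nnc(-c2ccc(C(=O)N/N=C/c3cccnc3)cc2)o1` gives 167000 nM. Compound 3 thus stands second highest of the three numbers, with compound 2 nearest, the step of a 1.0-fold higher number from compound 2 to compound 3 (0.02 log units; within the scatter) lying within the scatter, and compound 1 furthest, the step of a 2.1-fold lower number from compound 1 to compound 3 (0.33 log units; beyond the scatter) lying beyond it.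

Compound 4 `COc1ccccc1-c1nnc(-c2ccc(C(=O)N/N=C/c3ccccc3F)cc2)o1` differs from compound 3 in one place: 2-fluorophenyl in place of pyridin-3-yl on a carbon with a double bond to nitrogen. Within the data shown here, two measured steps bear on this. The step of a 2.1-fold lower number from compound 1 to compound 3 (0.33 log units; beyond the scatter) shows that exchanging a fluorophenyl for the pyridin-3-yl lowered the number modestly, so the reverse exchange would be expected to raise it. The step of a 2.2-fold lower number from compound 1 to compound 2 (0.34 log units; beyond the scatter) shows that a fluorine at the 3-position and a nitro group at the 2-position of the phenyl ring gave numbers differing modestly, so the 2-fluorophenyl is expected to land somewhere between these. The step of a 1.4-fold higher number from compound 3 to compound 4 (0.16 log units; within the scatter) is therefore expected to be small and upward, possibly within the scatter. Compound 4 is estimated at 240000 nM, within 120000 nM to 480000 nM.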

Compound 4, half-maximal inhibitory concentration: 313000 nM
Compound 4: the middle estimate sits 1.3-fold (0.12 log units) below what was measured; measured number inside the range.
By their numbers in this assay, from the lowest: compounds 2, 3, 4 and 1 (each within the scatter of the next, the first and the last beyond it).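

In this assay, moving the fluorine from 3-fluorophenyl to 2-fluorophenyl gives no readable difference (a 1.1-fold lower number from compound 1 to compound 4 (0.05 log units; within the scatter)), so these two placements of fluorine are not told apart at this position. The exchange of pyridin-3-yl for 2-fluorophenyl also stays within the scatter (a 1.9-fold higher number from compound 3 to compound 4 (0.27 log units; within the scatter)), as does fluoro in place of nitro on an aromatic carbon (a 1.9-fold higher number from compound 2 to compound 4 (0.29 log units; within the scatter)). Compound 4 therefore cannot be separated from any of the three earlier compounds, although compound 1 and compound 2 do stand apart, and the hydrazone aryl group appears to have only a shallow effect across these four compounds.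

Nothing available here explains any of these numbers. It remains open whether an amine or a carboxylic acid on this aromatic ring, or a saturated ring in its place, would move the number further than the groups shown.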